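Amide substituent change on the shared core: compound 4

A few compounds are considered here, and "the series" means these few. Any claim that something is new, unique, unknown or untested is made for them only; others in the source may bear on it.

Compound 2 `CCCCCCCCCCCC(=O)OC[C@H](CSC[C@@H](N)C(=O)NC(C)CCc1ccccc1)OC(=O)CCCCCCCCCCC` gives the lowest number of the three in an assay on HEK293 cells for agonist activity at Toll-like receptor 2 (Homo sapiens) (on this read-out higher numbers stand for an effect only at larger amounts of compound and lower numbers for an effect already at smaller amounts), at 160 nM; compound 3 `CCCCCCCCCCCC(=O)OC[C@H](CSC[C@@H](N)C(=O)N[C@@H](CO)C(=O)NCCOCCOCCOCCC(=O)O)OC(=O)CCCCCCCCCCC` gives 4940 nM and compound 1 `CCCCCCCCCCCC(=O)OC[C@H](CSC[C@@H](N)C(=O)N[C@H](C)CO)OC(=O)CCCCCCCCCCC` gives 22200 nM, both beyond the scatter above compound 2. Compound 4 `CCCCCCCCCCCC(=O)OC[C@H](CSC[C@@H](N)C(=O)NCCCCN)OC(=O)CCCCCCCCCCC` differs from compound 2 only at the amide-type nitrogen: 4-aminobutyl in place of 1-methyl-3-phenylpropyl on an amide-type nitrogen. Among the compounds with values here, the single step that bears on this change is a 140-fold lower number from compound 1 to compound 2 (2.14 log units; beyond the scatter), which ran from 1-(hydroxymethyl)ethyl, a group with a hydrogen-bond donor and no ring, to the ring-bearing group now removed. Bringing in a chain with a donor and no ring is expected to undo much of that step, so compound 4 is expected to show a large rise in this assay, a 31-fold higher number from compound 2 to compound 4 (1.49 log units; beyond the scatter). The estimate for compound 4 is 5000 nM, with a range from 800 nM to 30000 nM.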

Compound 4, half-maximal effective concentration: 1040 nM
The estimate for compound 4 lay 4.8-fold (0.68 log units) above the measured number; the measured number falls inside the stated range.
By their numbers in this assay, from the lowest: compound 2; then compound 4; then compound 3; then compound 1.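

In this assay 4-aminobutyl in place of 1-methyl-3-phenylpropyl on the amide-type nitrogen gives a 6.5-fold higher number from compound 2 to compound 4 (0.81 log units; beyond the scatter), while 4-aminobutyl in place of 1-(hydroxymethyl)ethyl gives a 21-fold lower number from compound 1 to compound 4 (1.33 log units; beyond the scatter). A group with no ring at this position can therefore still give a number well under that of compound 1, although compound 2 keeps the lowest number. No measurement here accounts for either step.

On these data alone, whether the terminal amine or the chain itself carries this difference remains open. Plain butyl, a longer chain ending in an amine, and a chain ending in a carboxylic acid would help separate the two.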